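The source may hold more compounds than are shown below. What is called first, only, known or untested is meant among the compounds shown, and "the series" means these compounds.

Four compounds share one core. Compound 1 `Cc1c(OCCCCOc2ccc(C(=O)O)cc2)ccc(C(=O)CC2CCCC2)c1C` and compound 3 `Cc1c(OCCCCOc2cccc(C(=O)O)c2)ccc(C(=O)CC2CCCC2)c1C` each carry a carboxyphenyl tail on the chain oxygen; in an assay on HEK293 cells for positive allosteric modulation of metabotropic glutamate receptor 3 (Rattus norvegicus), read by thallium flux, with a stated time of 2.5 min (on this read-out higher numbers stand for an effect only at larger amounts of compound and lower numbers for an effect already at smaller amounts), compound 1 gives "not determined" (no result reported) and compound 3 gives "not determined" (no result reported), so for both no result was reported. Compound 2 `Cc1c(OCCCCOc2ccc(C(=O)O)c(Cl)c2)ccc(C(=O)CC2CCCC2)c1O`, which bears a hydroxyl on its core and a 4-carboxy-3-chlorophenyl tail, gives 2250 nM in this assay. Compound 3 thus stands without a single number, and compound 1 is the one further entry without a number. Compound 4 `Cc1c(OCCCCOc2ccc(C(=O)O)c(Cl)c2)ccc(C(=O)CC2CCCC2)c1C` differs from compound 3 in one place: 4-carboxy-3-chlorophenyl in place of 3-carboxyphenyl on an oxygen on a saturated carbon. Within the data shown here, no measured pair mirrors this step, so neither its size nor its direction in this assay can be read from the data at hand. Since compound 2 gives 2250 nM in this assay, compound 4 is expected at about 2000 nM, within a range of 600 nM to 8000 nM.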

Compound 4, half-maximal effective concentration: > 10000 nM
Compound 4: a limit, no number; the forecaster's own chance of this, stated with the estimate: 25%; at least 5.0-fold (0.69 log units) between middle value and limit.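

With the 4-carboxy-3-chlorophenyl tail held the same, the group on the aromatic carbon of the core now shows an effect: this assay gives an at least 4.4-fold higher number from compound 2 to compound 4 (0.64 log units; beyond the scatter), with methyl in place of hydroxy. The result for compound 4 is a limit, not a number: the limit of > 10000 nM in this assay, at which 1 of the 4 values shown sits.

Going by these compounds, the step from compound 3 to compound 4 cannot be read, so what the change of tail does on its own stays open. On these data alone, whether an amine or a methoxy group on that aromatic carbon would behave like hydroxy or like methyl also stays open.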